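From 4-isobutylphenyl to pyridin-2-yl in liver microsomes

The source may hold more compounds than are shown below. What is called first, only, known or untested is meant among the compounds shown, and "the series" means these compounds.

Compound 1 (`CCn1c([C@@H](C)NS(=O)(=O)c2ccccc2)nc2ccc(C(F)(F)F)cc21`) gives 14 mL.min-1.g-1 as a measured number
Compound 2 (`CCn1c([C@@H](C)NS(=O)(=O)c2ccc(C)cc2)nc2ccc(C(F)(F)F)cc21`) gives > 100 mL.min-1.g-1 as a limit of the assay
Compound 3 (`CCn1c([C@@H](C)NS(=O)(=O)c2ccc(CC(C)C)cc2)nc2ccc(C(F)(F)F)cc21`) gives > 100 mL.min-1.g-1 as a limit of the assay

All three values come from an ADME assay (liver) for metabolic stability, with Liver microsome (Homo sapiens) as the target, read by LC-MS, using microsomes and NADPH, with a stated time of 5 min, at 37 degrees C (on this read-out higher numbers stand for fast clearance and lower numbers for slow clearance), and only compound 1 has an exact number. Compound 3 stands at a limit (the limit of > 100 mL.min-1.g-1 in this assay, at which 2 of the 3 values shown sit). Compound 4 (`CCn1c([C@@H](C)NS(=O)(=O)c2ccccn2)nc2ccc(C(F)(F)F)cc21`) differs from it as follows (pyridin-2-yl in place of 4-isobutylphenyl on a sulfonyl sulfur): pyridin-2-yl in place of 4-isobutylphenyl on a sulfonyl sulfur.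

Going by the values given here, two measured steps bear on this change. Adding methyl gave an at least 7.1-fold higher number from compound 1 to compound 2 (0.85 log units; beyond the scatter) and adding isobutyl gave an at least 7.1-fold higher number from compound 1 to compound 3 (0.85 log units; beyond the scatter), both beyond the scatter. The step that the two limits leave unreadable from compound 2 to compound 3 cannot be used, since both of its ends are limits. Among the compounds with values here, compound 4 loses the isobutyl and so resembles compound 1 (14 mL.min-1.g-1) more closely, although no measured step covers pyridin-2-yl itself. A clear fall is therefore expected, and the estimated size is an at least 8.3-fold lower number from compound 3 to compound 4 (0.92 log units; beyond the scatter). For compound 4 the expected value is 12 mL.min-1.g-1, with an estimated range from 4 mL.min-1.g-1 to 40 mL.min-1.g-1.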

Compound 4, intrinsic clearance in microsomes: < 3 mL.min-1.g-1
Compound 4 ended at the assay's limit; the forecaster's own chance of this, stated with the estimate: 10%; middle value at least 4.0-fold (0.60 log units) from the limit.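

Compound 4 gives a limit of the read-out and not a number, at the low end of this assay: the limit of < 3 mL.min-1.g-1 in this assay, at which 1 of the 4 values shown sits.

Pyridin-2-yl in place of phenyl gives an at least 4.6-fold lower number from compound 1 to compound 4 (0.66 log units; beyond the scatter), so changing the ring itself on the sulfonyl sulfur moves the number, whereas the earlier steps changed only what was added to a phenyl ring. On these data alone, the steps from the two compounds at the high limit, an at least 33-fold lower number from compound 2 to compound 4 (1.52 log units; beyond the scatter) and an at least 33-fold lower number from compound 3 to compound 4 (1.52 log units; beyond the scatter), span nearly the whole range that the assay can read, and their true sizes stay unknown with limits at both ends.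

As far as these compounds go, how far compound 4 lies past its limit remains open. Also open, from the compounds shown here alone, is whether pyridin-3-yl would act like pyridin-2-yl, and whether a methyl group on the pyridin-2-yl ring would raise the number again, as it did on phenyl.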